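Acid series: swapping the aryl ether tail for phenyl

The source may hold more compounds than are shown below. What is called first, only, known or untested is meant among the compounds shown, and "the series" means these compounds.

Compound 3 `CC(Oc1ccc(Oc2ccc(F)cc2)cc1)C(=O)Cn1nnc(-c2ccc(C(=O)O)cc2)n1` stands lowest of the three numbers in a physicochemical assay for lipophilicity, read by HPLC, tested at 5 mM; a lower number here means a more polar compound, a higher number a more lipophilic compound: compound 3 gives 2.7. Its nearest neighbour is compound 1 `CC(Oc1ccc(Oc2ccc(F)cc2)cc1)C(=O)Cn1nnc(-c2ccccc2)n1`, which in this assay gives 5.3; compound 2 `COC(=O)c1ccc(-c2nnn(CC(=O)C(C)Oc3ccc(-c4ccccc4)cc3)n2)cc1` gives 5.4. Going by the values given here, the one measured step that changes a single place, a number 2.60 log units lower from compound 1 to compound 3 (beyond the scatter), concerns the carboxy group and not the change at hand. Compound 4 `CC(Oc1ccc(-c2ccccc2)cc1)C(=O)Cn1nnc(-c2ccc(C(=O)O)cc2)n1` differs from compound 3 by phenyl in place of 4-fluorophenoxy on an aromatic carbon. Among the compounds with values here, no measured step covers this replacement; compound 1 and compound 2 differ in two places at once, and their numbers lie close together. Compound 4 is expected to move little, estimated at 2.5 (range 1.9 to 3.1), with the step of a number 0.20 log units lower from compound 3 to compound 4 (within the scatter) expected to remain near the scatter.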

Compound 4, partition coefficient: 2.6
The estimate for compound 4 lay 0.10 log units below the measured number, within the range that was stated.
By their numbers in this assay, from the lowest: compounds 4 and 3 (each within the scatter of the next); then compounds 1 and 2 (each within the scatter of the next).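

In this assay, going by these compounds alone, the step of a number 0.10 log units lower from compound 3 to compound 4 (within the scatter) gives the first single-place reading of phenyl in place of 4-fluorophenoxy, and it stays within the scatter in the acid series. The step of a number 2.80 log units lower from compound 2 to compound 4 (beyond the scatter), hydrogen in place of methyl on the ester oxygen, is large and shows a second large drop tied to the acid, now with the phenyl tail. Nothing available accounts for either step.

Going by these compounds, whether the tail swap stays this quiet without the acid remains open, as does the outcome with a primary amide or an amine in place of the carboxy group.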